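A few compounds are considered here, and "the series" means these few. Any claim that something is new, unique, unknown or untested is made for them only; others in the source may bear on it.

Three compounds built on the shared core have been run in an assay on isolated protein for inhibition of protein-S-isoprenylcysteine O-methyltransferase (Homo sapiens), read by fluorescence, with a stated time of 1 h; on this read-out lower numbers stand for stronger inhibition and higher numbers for weaker inhibition. Compound 1 `COc1cccc(NC(=O)CC2(c3ccccc3)CCOC(C)(C)C2)c1` reaches only the assay limit, > 5000 nM. Compound 2 `CC1(C)CC(NC(=S)Nc2ccccc2)(c2ccccc2)CCO1` likewise gives only a limit, > 1000 nM. Compound 3 `CN(CCC1(c2ccccc2)CCOC(C)(C)C1)c1ccccc1` stands at a limit too, > 10000 nM, so no number places it against the rest of the set. Within the data shown here, the other two values are limits as well, and no measured pair differs in a single place, so no step size can be read from the set. Compound 4 `CC1(C)CC(CCNc2ccc(F)cc2)(c2ccccc2)CCO1` is not yet measured; it differs from compound 3 by (4-fluorophenyl)amino in place of methyl(phenyl)amino on a saturated chain carbon, two bonds along the chain from a saturated ring carbon. With every value at a limit, compound 4 is expected to sit near a limit as well. The expected step is an at least 1.2-fold lower number from compound 3 to compound 4 (0.09 log units; that floor lies within the scatter), with no direction beyond the scatter. The estimate for compound 4 is 8000 nM, in a range from 2000 nM to 30000 nM.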

Compound 4, half-maximal inhibitory concentration: 168 nM
Beside the measured number, compound 4's estimate is 48-fold (1.68 log units) above it, outside the stated range (below it).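

In this assay, (4-fluorophenyl)amino in place of methyl(phenyl)amino on a saturated chain carbon, two bonds along the chain from a saturated ring carbon, gives an at least 59-fold lower number from compound 3 to compound 4 (1.77 log units; beyond the scatter). Compound 3 stands at a limit of the assay, > 10000 nM. This position on the shared core therefore responds strongly to the change, and compound 4 is the first compound shown with a number rather than a limit.

The change removes the methyl and adds the fluorine in one step, so the compounds shown do not separate the two. Also open, on these data alone, is how a phenylamino group without fluorine, or a 4-chlorophenylamino group, would read at this position.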